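Methoxy to hydroxy on the pyrazole-attached aryl ring

The source may report more compounds than this note shows. Statements on the series, on what has been measured and on what is new or still open speak of the compounds shown alone.

Measured compounds in a functional assay on UACC-62 cells (Homo sapiens) for inhibition, read by sulforhodamine B assay, with a stated time of 48 h; on this read-out lower numbers stand for higher toxicity in this test and higher numbers for lower toxicity in this test:
- compound 1, `O=C(Nc1cccc(-n2cc(-c3ccncc3)c(-c3ccc(Cl)c(O)c3)n2)c1)Nc1cccc(C(F)(F)F)c1`: 21900 nM
- compound 2, `COc1cc(-c2nn(-c3cccc(NC(=O)c4cccc(C(F)(F)F)c4)c3)cc2-c2ccncc2)ccc1Cl`: a value reported only as the assay limit, > 50000 nM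
- compound 3, `COc1cc(-c2nn(-c3cccc(NC(=O)Nc4ccc(Cl)c(Cl)c4)c3)cc2-c2ccncc2)ccc1Cl`: 4490 nM

Compound 3 holds the lowest of the two numbers in this assay; the nearest is compound 1, which gives 21900 nM. Going by the values given here, the single measured step, an at least 11-fold lower number from compound 2 to compound 3 (1.04 log units; beyond the scatter), concerns the group on the carbonyl carbon, and one value in it sits at the limit (the limit of > 50000 nM in this assay, at which 1 of the 3 values shown sits).

Compound 4, `O=C(Nc1cccc(-n2cc(-c3ccncc3)c(-c3ccc(Cl)c(O)c3)n2)c1)Nc1ccc(Cl)c(Cl)c1`, differs from compound 3 by hydrogen in place of methyl on an oxygen on an aromatic ring. Among the compounds with values here, no measured step covers this change; compound 1 and compound 3 differ in two places at once, so their values alone say nothing about it. The expectation is therefore a step of a 1.2-fold higher number from compound 3 to compound 4 (0.09 log units; within the scatter) in this assay, not beyond the scatter. For compound 4 the estimate is 5500 nM, within 2000 nM to 16000 nM.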

Compound 4, concentration lethal to 50% of the cells: 29200 nM
The estimate for compound 4 lay 5.3-fold (0.73 log units) below the measured number; measured number outside the range, above it.
By their numbers in this assay, from the lowest: compound 3; then compounds 1 and 4 (each within the scatter of the next). At a limit, above all of these: compound 2.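

Hydrogen in place of methyl on this oxygen gives a 6.5-fold higher number from compound 3 to compound 4 (0.81 log units; beyond the scatter) in this assay, the first direct reading of this position, and it shows that the methoxy-to-hydroxy change alone moves the number beyond the scatter. With hydroxy kept, 3,4-dichlorophenyl in place of 3-(trifluoromethyl)phenyl gives a 1.3-fold higher number from compound 1 to compound 4 (0.12 log units; within the scatter), so the two aryl groups are not separated in this pair. Nothing measured here accounts for the methoxy-to-hydroxy step.

On these data alone, whether that step holds with 3-(trifluoromethyl)phenyl on the amide-type nitrogen remains open. So does the reading of an ethoxy or amino group in place of methoxy.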